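This account rests on a few compounds, and the source may have more. Where it says the series, first, only, none or still open, it means among the compounds named here.

Going by the values given here, compound 1 `NC(=O)c1c(NC(=O)c2ccccc2Cl)sc2c1CCN(Cc1ccccc1)C2` is tested in a functional assay on HeLa cells (Homo sapiens) for antiproliferative activity, with a stated time of 24 h (on this read-out higher numbers stand for weaker inhibition and lower numbers for stronger inhibition), where compound 1 gives 38400 nM, the only plain number in this set. Its companion compound 2 `NC(=O)c1c(NC(=O)c2ccccc2Cl)sc2c1CCN(Cc1ccccc1F)C2` returns in this assay a limit of the assay, > 50000 nM, rather than a number. Among the compounds with values here, the step of an at least 1.3-fold higher number from compound 1 to compound 2 (0.11 log units; that floor lies within the scatter) is the only measured change here, and it swaps fluoro for hydrogen on an aromatic carbon. Compound 3 `CSc1ccccc1NC(=S)N1CCc2c(sc(NC(=O)c3ccccc3Cl)c2C(N)=O)C1` differs from compound 1 in another place: a group of 11 heavy atoms (8 carbon, 1 nitrogen, 2 sulfur; one six-membered aromatic ring of carbon only) in place of a group of 7 heavy atoms (7 carbon; one six-membered aromatic ring of carbon only), on an amine nitrogen in a ring. Within the data shown here, no measured step matches this change, so the fluorine step gives no guide to its size or direction, and the one limit of > 50000 nM in this assay, at which 1 of the 2 values shown sits, shows only that one of the two values sits where the assay stops counting. Compound 3 is therefore expected to stay weak, with an expected step of a 1.3-fold lower number from compound 1 to compound 3 (0.11 log units; within the scatter) that need not go beyond the scatter. The estimate for compound 3 in this assay is 30000 nM, within 8000 nM to 60000 nM.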

Compound 3, half-maximal inhibitory concentration: 43600 nM
For compound 3 the middle estimate is 1.5-fold (0.16 log units) below the measured one; the range from low to high includes it.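

In this assay, putting the larger sulfur-bearing group on the amine nitrogen in a ring in place of benzyl gives a 1.1-fold higher number from compound 1 to compound 3 (0.06 log units; within the scatter). This new group, unlike benzyl, carries a hydrogen-bond donor and hydrogen-bond acceptors, yet this substantial change at this position leaves the value within the usual scatter of the assay. Set against the fluorinated benzyl, the same position gives an at least 1.1-fold lower number from compound 2 to compound 3 (0.05 log units; that floor lies within the scatter), a floor rather than a full step, and compound 2 remains a limit of the assay, not a number: the limit of > 50000 nM in this assay, at which 1 of the 3 values shown sits.

What the compounds shown leave open is whether any group on this nitrogen can lower the number beyond the scatter, such as a small methyl, an acetyl or a chain ending in a carboxylic acid. As far as these compounds go, all three compounds also share the rest of the core, so the effect of changes elsewhere on it remains unknown.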